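This account rests on a few compounds, and the source may have more. Where it says the series, first, only, none or still open, it means among the compounds named here.

The series is a small set of compounds built on a shared core, and the question is how each fares in an ADME assay on HEK293 cells (Homo sapiens) for cytotoxicity, read by CCK-8 assay and cell counting, with a stated time of 2 days; on this read-out lower numbers stand for stronger inhibition and higher numbers for weaker inhibition. Compound 1 `Oc1cccc(-c2cc(-c3cccnc3)nc(-c3cccc(Cl)c3)c2)c1` has no number in this assay: for compound 1 the entry reads "not determined" (no result reported). Compound 2 `Oc1cccc(-c2cc(-c3cccc(Cl)c3)nc(-c3ccccn3)c2)c1` is in the same position: for compound 2 the entry reads "not determined" (no result reported). Among the compounds with values here, compound 3 `Oc1cccc(-c2cc(-c3cccs3)nc(-c3ccccc3Cl)c2)c1` is therefore the only compound with a result: in this assay compound 3 gives 2600 nM, and it stands alone, with nothing measured beside it to rank it against.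

Compound 4 `Oc1cccc(-c2cc(-c3cccc(Cl)c3)nc(-c3cccs3)c2)c1` has not yet been measured. Its structure differs from that of compound 3 in a single respect, and the two contain the same atoms joined differently: 3-chlorophenyl in place of 2-chlorophenyl on an aromatic carbon. Within the data shown here, no step between two measured compounds is available to gauge what such a change does in this assay.

With only compound 3 to go on, the expectation for compound 4 is a step of no real size, none beyond the usual scatter, in either direction: the estimated step is no change at the digits printed from compound 3 to compound 4 (within the scatter). Among the measured compounds shown here, compound 4 is accordingly expected to give about 2600 nM in this assay, with a plausible range from 1000 nM to 7000 nM, resting on the single value that compound 3 shows.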

Compound 4, half-maximal inhibitory concentration: 3150 nM
For compound 4 the middle estimate is 1.2-fold (0.08 log units) below the measured one; measured number inside the range.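

The result gives the series its first readable step: with 3-chlorophenyl in place of 2-chlorophenyl on the aromatic carbon next to the ring nitrogen, this assay shows a 1.2-fold higher number from compound 3 to compound 4 (0.08 log units; within the scatter) and thus no difference that can be told from repeat measurement. With a thiophen-2-yl group on the same ring and a 3-hydroxyphenyl group held constant, the chlorine can therefore occupy either of these two places on the phenyl group without the read-out separating the two compounds, a point that compound 3 alone could not make. Nothing offered here accounts for this result or says what the two compounds do to the cells.

As far as these compounds go, whether the same holds when thiophen-2-yl gives way to another ring stays open, since the entries for compound 1 and compound 2, which carry the pyridine-type partners, hold no number to test it against. Also open, from the compounds shown here alone, is what a 4-chlorophenyl group, or an amine or a carboxylic acid in place of the chlorine, would do at this position.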